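The source may report more compounds than this note shows. Statements on the series, on what has been measured and on what is new or still open speak of the compounds shown alone.

Measured so far:
compound 1 `COc1ccc(-c2cc(NNC(=O)Nc3cc(Cl)nc(Cl)c3)nc3c2cnn3C)cc1` gives 520 nM in an assay on isolated protein for binding affinity to sphingosine 1-phosphate receptor 2 (Homo sapiens), read by surface plasmon resonance; on this read-out higher numbers stand for weaker binding and lower numbers for tighter binding
compound 2 `COc1ccc(-c2cc(NNC(=O)Nc3cc(Cl)nc(Cl)c3)nc3c2c(C)nn3C)cc1` gives 1020 nM in this assay

Compound 1 holds the lower of the two numbers shown in this assay; compound 2 sits a 2.0-fold higher number from compound 1 to compound 2 (0.29 log units; within the scatter), so the two are not separated beyond the scatter. Going by the values given here, the only measured step, a methyl in place of hydrogen on an aromatic carbon of the shared core, changes nothing that can be read as a trend.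

Compound 3 `Cn1ncc2c(-c3ccccc3)cc(NNC(=O)Nc3cc(Cl)nc(Cl)c3)nc21` differs from compound 1 by hydrogen in place of methoxy on an aromatic carbon. Among the compounds with values here, no measured pair touches the methoxy group or this aryl ring, so nothing directly bears on the change. Within the data shown here, the single step available, from compound 1 to compound 2, stayed within the scatter, which gives no ground to expect a large shift in either direction here; the estimate is therefore kept close to compound 1 with a wide range.

Compound 3 is expected to give 800 nM in this assay, within about 250 nM to 2500 nM, which would mean an estimated step of a 1.5-fold higher number from compound 1 to compound 3 (0.19 log units; within the scatter).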

Compound 3, dissociation constant: 1020 nM
Compound 3: the middle estimate sits 1.3-fold (0.11 log units) below what was measured; low and high end bracket the measured number.
By their numbers in this assay, from the lowest: compounds 1, 2 and 3 (each within the scatter of the next).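

In this assay, the change from 4-methoxyphenyl to phenyl gives a 2.0-fold higher number from compound 1 to compound 3 (0.29 log units; within the scatter), so at this position on the aryl ring, para to a large group, the methoxy group can give way to hydrogen without a step beyond the scatter. Going by these compounds alone, this is the first measured change on this ring, as the earlier step, a 2.0-fold higher number from compound 1 to compound 2 (0.29 log units; within the scatter), concerned a methyl on the shared core, and neither step sets the compounds apart. No available evidence bears on this result.

The compounds shown leave open whether any other group at this position would give a step beyond the scatter, for example an amine, a carboxylic acid or a longer alkoxy chain. With only hydrogen and methoxy compared here, no trend across substituents on this ring can be drawn.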